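The source may report more compounds than this note shows. Statements on the series, on what has been measured and on what is new or still open speak of the compounds shown alone.

Measured compounds:
- compound 1, `O=S(=O)(NCCCNCc1ccc(Cl)cc1)c1cc(C(F)(F)F)cc(C(F)(F)F)c1`, 2300 nM
- compound 2, `COc1ccc(CNCCCNS(=O)(=O)c2cc(C(F)(F)F)cc(C(F)(F)F)c2)cc1OC`, 5300 nM
- compound 3, `O=S(=O)(NCCCNCc1ccccc1Cl)c1cc(C(F)(F)F)cc(C(F)(F)F)c1`, 11000 nM

All three share one core and differ only in the aryl group carried on a saturated chain carbon bound to an amine nitrogen. In a toxicity assay on MCF-10A cells (Homo sapiens) for inhibition, read by MTT assay, with a stated time of 72 h (on this read-out lower numbers stand for stronger inhibition of growth and higher numbers for weaker inhibition of growth), compound 3 gives the highest number of the three, so its inhibition of growth is the weakest seen here; compound 2 is nearest to it and compound 1 furthest, as the steps of a 2.1-fold higher number from compound 2 to compound 3 (0.32 log units; beyond the scatter) and a 4.8-fold higher number from compound 1 to compound 3 (0.68 log units; beyond the scatter) show.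

Compound 4, `COc1ccc(CNCCCNS(=O)(=O)c2cc(C(F)(F)F)cc(C(F)(F)F)c2)cc1`, has not yet been measured. It differs from compound 3 in one place: 4-methoxyphenyl in place of 2-chlorophenyl on a saturated chain carbon bound to an amine nitrogen.

Within the data shown here, two measured steps bear on this change. Moving from 4-chlorophenyl to 2-chlorophenyl gave a 4.8-fold higher number from compound 1 to compound 3 (0.68 log units; beyond the scatter), and moving from 3,4-dimethoxyphenyl to 2-chlorophenyl gave a 2.1-fold higher number from compound 2 to compound 3 (0.32 log units; beyond the scatter). The 4-methoxyphenyl group that enters carries a methoxy group like compound 2 and a single substituent like compound 1, so reversing the direction of both steps suggests a lower number than compound 3 in this assay. For compound 4 the expected step is a 3.1-fold lower number from compound 3 to compound 4 (0.50 log units; beyond the scatter), a move toward stronger inhibition. Compound 4 is therefore estimated at 3500 nM, with a range from 1500 nM to 8000 nM.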

Compound 4, concentration for 50% growth inhibition: 3100 nM
Estimate against measurement, compound 4: 1.1-fold (0.05 log units) above; low and high end bracket the measured number.
By their numbers in this assay, from the lowest: compounds 1, 4 and 2 (each within the scatter of the next, the first and the last beyond it); then compound 3.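

The step to the 4-methoxyphenyl group, a 3.5-fold lower number from compound 3 to compound 4 (0.55 log units; beyond the scatter) in this assay, leaves compound 3 as the weakest inhibitor of growth of the four, the only one beyond the scatter from every other compound. Neither of the other new steps can be told from the scatter: removing one methoxy group gives a 1.7-fold lower number from compound 2 to compound 4 (0.23 log units; within the scatter), and methoxy in place of chloro on an aromatic carbon gives a 1.3-fold higher number from compound 1 to compound 4 (0.13 log units; within the scatter), so compound 4 cannot be ranked against compound 1 or compound 2, even though those two lie beyond the scatter of each other. Among the groups shown, the step from the 4-chlorophenyl group to the 2-chlorophenyl group is therefore readable while the exchange of chloro for methoxy is not, but nothing shown explains this difference.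

A 2-methoxyphenyl group would test whether the weaker reading follows the 2-substituted ring or belongs to the 2-chlorophenyl group alone. A plain phenyl group would show how these substituted rings compare with a ring carrying no substituent at all.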